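Swapping the amine on the sulfonyl sulfur of compound 1

The source may report more compounds than this note shows. Statements on the series, on what has been measured and on what is new or still open speak of the compounds shown alone.

Of the compounds shown here, three have been measured in an assay on CHO cells for displacement of a labelled ligand from prostaglandin D2 receptor 2 (Homo sapiens), read by scintillation counting; a lower number here means a stronger inhibitor, a higher number a weaker inhibitor. Compound 1, with the structure `Cc1ccc(S(=O)(=O)NC(C)C)cc1C#Cc1cc(Cl)ccc1OCC(=O)O`, gives 3.4 nM, the lowest of the three numbers. Compound 2, with the structure `CCCS(=O)(=O)c1cccc(C#Cc2c(Cl)cccc2OCC(=O)O)c1`, gives 55 nM, and compound 3, with the structure `O=C(O)COc1ccc(Cl)cc1C#Cc1ccc(F)cc1F`, gives 101 nM. Both gaps to compound 1 lie well beyond the usual scatter of repeated measurements, so compound 1 is the strongest inhibitor among the three. Among the compounds with values here, none of these pairs differs in only one place, so the three numbers show no isolated single-change step.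

Compound 4, with the structure `Cc1ccc(S(=O)(=O)N(C)CCN(C)C)cc1C#Cc1cc(Cl)ccc1OCC(=O)O`, keeps the whole of compound 1 except at one position: (2-(dimethylamino)ethyl)(methyl)amino in place of isopropylamino on a sulfonyl sulfur. Within the data shown here, no measured pair shows this kind of change, so the expectation rests on compound 1 alone. The change sits at the edge of the molecule and replaces one amine with another, and such a change is expected to cost some potency rather than none, with a step from compound 1 to compound 4 of about a 2.9-fold higher number from compound 1 to compound 4 (0.47 log units; beyond the scatter) expected in this assay, toward a higher number. Compound 4 is therefore estimated to give 10 nM in this assay, with a likely range from 2 nM to 60 nM.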

Compound 4, inhibition constant: 369 nM
The estimate for compound 4 lay 37-fold (1.57 log units) below the measured number; measured number above the stated range.
By their numbers in this assay, from the lowest: compound 1; then compounds 2 and 3 (each within the scatter of the next); then compound 4.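

In this assay, within the data shown here, the amine on the sulfonyl sulfur proves far from a neutral place to make a change: with the rest of compound 1 kept, this single swap gives a 110-fold higher number from compound 1 to compound 4 (2.04 log units; beyond the scatter), a large step and the first single-change step in this set. The swap also changes more than one thing at once, as isopropylamino counts 1 hydrogen-bond donor and 0 acceptors across 4 heavy atoms, whereas (2-(dimethylamino)ethyl)(methyl)amino counts 0 donors and 1 acceptor across 7 heavy atoms. Nothing measured here gives a reason for the step, so it stands as an observation about this one pair of amines.

The compounds shown leave open which part of the entering group goes with the higher number: the methyl that takes the place of the amide hydrogen, or the longer chain ending in dimethylamino. A plain dimethylamino group and a 2-(dimethylamino)ethylamino group on the same sulfur would help to separate these two parts, and a morpholine or a simple methylamino group would show how far the trend extends.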